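A few compounds are considered here, and "the series" means these few. Any claim that something is new, unique, unknown or untested is made for them only; others in the source may bear on it.

Measured in a functional assay on SF-295 cells (Homo sapiens) for inhibition, read by sulforhodamine B assay, with a stated time of 48 h; a lower number here means a stronger inhibitor of growth, a higher number a weaker inhibitor of growth:

compound 1 `COc1cc(OC)cc(-c2ccc(-c3ccc(C(=N)N)c(F)c3)s2)c1` gives 1590 nM
compound 2 `N=C(N)c1ccc(-c2ccc(-c3ccc(Cl)cc3)s2)cc1F` gives 691 nM
compound 3 `N=C(N)c1ccc(-c2ccc(-c3ccc(Cl)cc3)s2)cc1` gives 171 nM

Compound 1 stands highest of the three numbers in this assay; compound 2 is nearest to it and compound 3 furthest. The difference between the core of compound 1 and the core of compound 2 is not broken down here. Compound 2 and compound 3 share one core and differ in one place; the change from compound 2 to compound 3 is hydrogen in place of fluoro on an aromatic carbon and it gave a 4.0-fold lower number from compound 2 to compound 3 (0.61 log units; beyond the scatter).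

Compound 4 `COc1cc(OC)cc(-c2ccc(-c3ccc(C(=N)N)cc3)s2)c1` is not yet measured. It differs from compound 1 by hydrogen in place of fluoro on an aromatic carbon, the same change made on the core of compound 1, the place described in the same words. For the measured compounds named here, the step from compound 1 to compound 4 is expected to be a 3.8-fold lower number from compound 1 to compound 4 (0.58 log units; beyond the scatter), beside the earlier step, because a 4.0-fold lower number from compound 2 to compound 3 (0.61 log units; beyond the scatter) is the single example of this change and it was made on a different core, so the size carries some uncertainty. Compound 4 is therefore expected to give about 420 nM in this assay, with the estimate spanning from 150 nM to 1200 nM.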

Compound 4, concentration for 50% growth inhibition: 1820 nM
Beside the measured number, compound 4's estimate is 4.3-fold (0.64 log units) below it; the whole stated range lies below it.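

In this assay hydrogen in place of fluoro on the core of compound 1 gives a 1.1-fold higher number from compound 1 to compound 4 (0.06 log units; within the scatter) and so leaves no readable change on that core. The change does not carry over in size from one core to the other: the same change on two cores in this assay, a 4.0-fold lower number (0.61 log units; beyond the scatter) from compound 2 to compound 3 and a 1.1-fold higher number (0.06 log units; within the scatter) from compound 1 to compound 4, 4.6-fold (0.67 log units) apart, beyond the scatter of two such steps

This rests on a single step on each of two cores, so it shows only that the size of the change differed between these two pairs. It does not show which difference between the cores goes with the larger step, and it gives no rule for predicting the step on a further core.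

Still open is how the same change behaves on cores carrying a hydroxyl, an amine or a trifluoromethyl group in place of the chloro or methoxy groups shown here. Also open, going by these compounds, is whether a methyl or a nitrile at the same aromatic carbon would separate the two cores as fluoro and hydrogen do.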